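Para-halogen swap on the diarylethane series

The compounds below may be only part of what the source reports. "The series", "measured", "known", "first", "only" and "open" are said of these compounds alone.

Measured so far in a functional assay on HCT-116 cells (Homo sapiens) for antiproliferative activity, read by MTT assay, with a stated time of 72 h; on this read-out lower numbers stand for stronger inhibition and higher numbers for weaker inhibition:
- compound 1, `COc1cc(CCc2ccccc2)cc(OC)c1O`: 530 nM
- compound 2, `COc1cc(CCc2ccc(F)cc2)cc(OC)c1O`: 1190 nM
- compound 3, `COc1cc(CCc2ccccc2F)cc(OC)c1O`: 880 nM

Compound 2 gives the highest number of the three; its nearest neighbour is compound 3, within the scatter, while compound 1 sits beyond the scatter below it, as the step of a 2.2-fold higher number from compound 1 to compound 2 (0.35 log units; beyond the scatter) records. The other single change, a 1.7-fold higher number from compound 1 to compound 3 (0.22 log units; within the scatter), stays within the scatter.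

Compound 4, `COc1cc(CCc2ccc(Cl)cc2)cc(OC)c1O`, is the next member. It differs from compound 2 by chloro in place of fluoro on an aromatic carbon.

Neither measured step tests a chloro group; both concern fluoro in place of hydrogen on an aromatic carbon. Among the compounds with values here, the one at the same place, from compound 1 to compound 2, was modest, and the one from compound 1 to compound 3 was within the scatter. Within the data shown here, the halogen-for-halogen exchange has no direct precedent here, so the expectation in this assay is for no step beyond the scatter from compound 2, with a slight lean toward a lower number because the comparison series starts from 1190 nM, the highest value seen.

Compound 4 is therefore estimated at 1000 nM, within 450 nM to 2400 nM, an expected step of a 1.2-fold lower number from compound 2 to compound 4 (0.08 log units; within the scatter).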

Compound 4, half-maximal inhibitory concentration: 330 nM
Compound 4: the middle estimate sits 3.0-fold (0.48 log units) above what was measured; the measured number lies below the stated range.
By their numbers in this assay, from the lowest: compounds 4, 1, 3 and 2 (each within the scatter of the next, the first and the last beyond it).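

In this assay, within the data shown here, the halogen at this place, para to a large group, proves to matter: chloro in place of fluoro gives a 3.6-fold lower number from compound 2 to compound 4 (0.56 log units; beyond the scatter) and is the only step toward a lower number that lies beyond the scatter. At the same place, chloro in place of hydrogen gives a 1.6-fold lower number from compound 1 to compound 4 (0.21 log units; within the scatter) and stays within the scatter, whereas fluoro in place of hydrogen gives a 2.2-fold higher number from compound 1 to compound 2 (0.35 log units; beyond the scatter) and lies beyond it. The two halogens therefore do not behave alike here, and the higher number of compound 2 is not shared by compound 4, so a halogen at this place does not by itself carry the number upward.

Still open, from the compounds shown here alone, is whether bromo, methyl or an amine at this place would stay with compound 4 and compound 1 or move toward compound 2, and whether chloro at the place that holds fluoro in compound 3 would repeat the result. Nothing shown here bears on why chloro and fluoro part at this place.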